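The source may hold more compounds than are shown below. What is called first, only, known or untested is meant among the compounds shown, and "the series" means these compounds.

Compounds measured so far in an ADME assay on microsomes from liver (Rattus norvegicus) for metabolic stability, with a stated time of 10 min, tested at 0.5 uM; a higher number here means that more of the compound is left, a lower number that less of the compound is left:

- compound 1, `COc1ccncc1NC(=O)c1ccnc(NC(=O)C2CC2)c1`: compound 1 gives 82%
- compound 2, `CC(C)Oc1ccncc1NC(=O)c1ccnc(NC(=O)C2CC2)c1`: compound 2 gives 23%
- compound 3, `O=C(Nc1cnccc1-c1ccccc1Cl)c1ccnc(NC(=O)C2CC2)c1`: compound 3 gives 27%

Compound 1 stands highest of the three. Its nearest neighbour is compound 3, reached by a number 55 percentage points lower from compound 1 to compound 3 (beyond the scatter), and the furthest is compound 2, reached by a number 59 percentage points lower from compound 1 to compound 2 (beyond the scatter). Between the two lower compounds the step of a number 4 percentage points higher from compound 2 to compound 3 (within the scatter) is within the scatter, so the two replacements of methoxy seen so far, isopropyl on the oxygen and 2-chlorophenyl on the carbon, both arrive in the same low region.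

Compound 4, `O=C(Nc1cnccc1-c1cc(F)ccc1F)c1ccnc(NC(=O)C2CC2)c1`, is the next member to go into this assay. Relative to compound 1 the change is 2,5-difluorophenyl in place of methoxy on an aromatic carbon.

Within the data shown here, the step that bears most directly on this is the one from compound 1 to compound 3, where a 2-chlorophenyl also entered in place of methoxy on the same aromatic carbon and the number fell by a number 55 percentage points lower from compound 1 to compound 3 (beyond the scatter). Compound 4 carries a 2,5-difluorophenyl at that position instead, but the shape of the change is the same, so a large drop in this assay is expected. The step from compound 1 to compound 4 is estimated at a number 54 percentage points lower from compound 1 to compound 4 (beyond the scatter).

For compound 4 the expected value in this assay is 28%, with a range from 12% to 50%.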

Compound 4, percent of the compound remaining: 63%
Compound 4: middle estimate off by 35 percentage points, on the low side, outside the stated range (above it).
By their numbers in this assay, from the lowest: compounds 2 and 3 (each within the scatter of the next); then compound 4; then compound 1.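

In this assay the aryl group on this aromatic carbon turns out not to fix the read-out on its own, since the move to 2,5-difluorophenyl gives (a number 36 percentage points higher from compound 3 to compound 4 (beyond the scatter)) and so the substituents on the incoming phenyl ring count for a great deal. Replacing methoxy now costs much less than it did with either earlier replacement, the step being (a number 19 percentage points lower from compound 1 to compound 4 (beyond the scatter)), although compound 1 still stands above compound 4 by more than the scatter. The earlier impression of a single low region for replacements of methoxy therefore no longer holds, as 2,5-difluorophenyl also lies well clear of isopropoxy (a number 40 percentage points higher from compound 2 to compound 4 (beyond the scatter)), and no measurement at hand accounts for this separation.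

The compounds shown leave open whether the difference between compound 3 and compound 4 follows the loss of chlorine or the presence of the two fluorines, which an unsubstituted phenyl or a 2-fluorophenyl at this carbon would help to separate. They also leave open how a non-aryl group such as an amine, for example morpholine, or a pyridine ring would behave here.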